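A few compounds are considered here, and "the series" means these few. Any claim that something is new, unique, unknown or untested is made for them only; others in the source may bear on it.

Measured compounds:
- compound 1, `Cc1ccc(-c2nc(N)nc(N)n2)cc1`: 1.92 in a physicochemical assay for lipophilicity; on this read-out higher numbers stand for higher lipophilicity and lower numbers for lower lipophilicity
- compound 2, `CCN(CC)c1c(C)n(-c2ccccc2)c(=O)n(C)c1=O`: 2.19 in this assay
- compound 3, `Nc1nc(N)nc(-c2cccc(C(F)(F)F)c2)n1`: 2.67 in this assay

Among these three numbers, compound 2 stands second highest. Its nearest neighbour is compound 1, whose value lies a little lower, a gap that falls within the usual scatter of repeated measurements, so the two cannot be told apart in this assay. The furthest is compound 3, whose value lies higher by a gap that does go beyond the scatter.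

The compound not yet measured is compound 4, `Cc1c(N(C)C)c(=O)n(C)c(=O)n1-c1ccccc1`. It differs from compound 2 in one place: dimethylamino in place of diethylamino on an aromatic carbon. Going by the values given here, no pair of the measured compounds shows this kind of change, so no measured step can be quoted for it. Since what leaves carries more heavy atoms than what enters, the account expects the number in this assay to fall, by a step beyond the scatter, from compound 2 to compound 4.

For compound 4 the estimate in this assay is 1.35, with a range from 0.85 to 1.85. The expected step is a number 0.84 log units lower from compound 2 to compound 4 (beyond the scatter).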

Compound 4, partition coefficient: 1.19
Compound 4: the middle estimate sits 0.16 log units above what was measured; low and high end bracket the measured number.
By their numbers in this assay, from the lowest: compound 4; then compounds 1 and 2 (each within the scatter of the next); then compound 3.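

Replacing diethylamino with dimethylamino on this aromatic carbon, ortho to a methyl group, gives a number 1.00 log units lower from compound 2 to compound 4 (beyond the scatter) in this assay, and this is the only step among the compounds shown that isolates a change in one place. The exchange leaves the count of hydrogen-bond donors and acceptors and the net charge as they were, while the heavy atoms of the group go from 5 to 3, so at this position a change confined to the amino substituent is enough to move the number beyond the scatter. No measurement shown accounts for the size of this step.

A single pair cannot show whether the number follows the length of the chains on this nitrogen in a regular way, and a primary amine or a dipropylamino group at the same carbon would extend the series in both directions. On these data alone, whether the same exchange gives a step of similar size on a different core, or at another place on this one, also remains open.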